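The source may report more compounds than this note shows. Statements on the series, on what has been measured and on what is new or still open speak of the compounds shown alone.

Measured so far:
compound 1, `N#Cc1cccnc1N1CCN(CC/C(=N/O)c2ccccc2)CC1`: 49%
compound 2, `CCO/N=C(\CCN1CCN(c2ccccc2)CC1)c1ccccc1`: 80%
compound 3, `CCO/N=C(\CCN1CCN(c2ccccc2C#N)CC1)c1ccccc1`: 82%

In a functional assay on HEK293 cells with D(4) dopamine receptor (Homo sapiens) as the target, read by FLIPR (on this read-out higher numbers stand for larger maximal responses and lower numbers for smaller maximal responses), compound 3 gives the highest of the three numbers. Compound 2 lies closest, and the step of a number 2 percentage points higher from compound 2 to compound 3 (within the scatter) keeps the two within the usual scatter, so they cannot be told apart. Compound 1 lies furthest away, and the gap between its value and that of compound 3 is beyond the scatter.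

Compound 4, `CCO/N=C(\CCN1CCN(c2ccccc2OC)CC1)c1ccccc1`, has not yet been measured in this assay. It differs from compound 3 in one place: methoxy in place of cyano on an aromatic carbon. Within the data shown here, the only measured step that touches the same spot is a number 2 percentage points higher from compound 2 to compound 3 (within the scatter), where cyano entered in place of hydrogen and the read-out hardly moved. No measured pair shows a methoxy entering, so the change from compound 3 to compound 4 has no direct precedent among these compounds. Because a number 2 percentage points higher from compound 2 to compound 3 (within the scatter) stayed within the scatter, no step beyond the scatter is expected for compound 4 in this assay either. The expected step of a number 4 percentage points lower from compound 3 to compound 4 (within the scatter) is therefore small. Compound 4 is estimated at 78%, within 60% to 92%.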

Compound 4, largest response reached (reported as efficacy), in percent of the reference or control that the assay uses: 76%
Beside the measured number, compound 4's estimate is 2 percentage points above it, and the stated range covers the measured number.
By their numbers in this assay, from the lowest: compound 1; then compounds 4, 2 and 3 (each within the scatter of the next).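

In this assay methoxy in place of cyano gives a number 6 percentage points lower from compound 3 to compound 4 (within the scatter) and methoxy in place of hydrogen gives a number 4 percentage points lower from compound 2 to compound 4 (within the scatter) so hydrogen, cyano and methoxy on this aromatic carbon, ortho to a large group, cannot be told apart by their maximal response. The earlier compounds shown here showed this for cyano alone, whereas now a second group, one that carries oxygen instead of nitrogen, also leaves the read-out within the scatter, although both groups still count 2 heavy atoms and 1 hydrogen-bond acceptor. Nothing available here explains why the read-out holds steady across these three compounds.

The compounds shown leave open whether this holds for groups of a different kind at the same carbon, such as an amine, a carboxylic acid or a longer chain like butoxy, and whether methoxy or cyano would behave the same way on the other carbons of the ring. From the compounds shown here alone, compound 1 differs from these compounds in more than one place, so the part each of its differences plays in its separate value also stays open.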